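Ethyl to propyl on the shared core

The source may hold more compounds than are shown below. What is called first, only, known or untested is meant among the compounds shown, and "the series" means these compounds.

In a functional assay on LNCaP cells (Homo sapiens) for inhibition, read by MTT assay (on this read-out higher numbers stand for weaker inhibition and lower numbers for stronger inhibition), compound 1 `CN1C(=O)/C(=C2\Nc3ccccc3\C2=N/O)c2ccccc21` gives 68900 nM and compound 2 `CCN1C(=O)/C(=C2\Nc3ccccc3\C2=N/O)c2ccccc21` gives 10300 nM. Among the measured compounds shown here, compound 2 therefore holds the lower of the two numbers so far, and the gap to compound 1 lies beyond the scatter.

The next structure, compound 3 `CCCN1C(=O)/C(=C2\Nc3ccccc3\C2=N/O)c2ccccc21`, turns ethyl into propyl: methyl in place of hydrogen on a saturated chain carbon, two bonds along the chain from an amide-type nitrogen in a ring. This places methyl in place of hydrogen on a saturated chain carbon, two bonds along the chain from an amide-type nitrogen in a ring.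

For the measured compounds named here, only one measured step bears on this change: a 6.7-fold lower number from compound 1 to compound 2 (0.83 log units; beyond the scatter), a modest step for methyl in place of hydrogen on a saturated chain carbon bound to an amide-type nitrogen in a ring. One step sets no trend, and its place differs from the new one. A smaller step in the same direction is therefore expected in this assay, towards a lower number, and it may not clear the scatter. The estimated step is a 1.7-fold lower number from compound 2 to compound 3 (0.23 log units; within the scatter). Compound 3 is expected at 6000 nM, with an estimated range of 2500 nM to 15000 nM.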

Compound 3, half-maximal inhibitory concentration: 77100 nM
Beside the measured number, compound 3's estimate is 13-fold (1.11 log units) below it; the measured number lies above the stated range.
By their numbers in this assay, from the lowest: compound 2; then compounds 1 and 3 (each within the scatter of the next).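

In this assay, lengthening the chain on the amide-type nitrogen in a ring does not give a steady trend: a methyl in place of hydrogen on a saturated chain carbon, two bonds along the chain from that nitrogen, gives a 7.5-fold higher number from compound 2 to compound 3 (0.87 log units; beyond the scatter) and so runs against the earlier step. The same kind of replacement thus points in opposite directions at its two places, and the outcome at this nitrogen depends on where along the chain the methyl enters. Ethyl in place of hydrogen on the chain carbon bound to that nitrogen gives a 1.1-fold higher number from compound 1 to compound 3 (0.05 log units; within the scatter), so the propyl chain keeps nothing of the advantage seen with ethyl, and among these three compounds only compound 2, with its steps to both others beyond the scatter, stands apart.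

From the compounds shown here alone, whether a butyl chain, a branched isopropyl group, or a chain ending in an amine or a carboxylic acid would stay near compound 2 or near compound 3 remains open. No measurement shown here explains why the series turns at the ethyl chain.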